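The source may hold more compounds than are shown below. What is called first, only, known or untested is meant among the compounds shown, and "the series" means these compounds.

In a functional assay on MGC-803 cells (Homo sapiens) for cytotoxicity, read by MTT assay, with a stated time of 3 days (a higher number here means a weaker inhibitor, a lower number a stronger inhibitor), the three urea analogues that share a core sit at the weak end. Compound 1 `Cc1cc(C)nc(Sc2ccc(NC(=O)Nc3ccccc3)cc2)n1` gives 40100 nM. Compound 2 `Cc1cccc(NC(=O)Nc2ccc(Sc3nc(C)cc(C)n3)cc2)c1` gives 25300 nM. Compound 3 `Cc1cc(C)nc(Sc2ccc(NC(=O)Nc3ccc(F)cc3)cc2)n1` gives > 50000 nM, which is a limit of the assay rather than a number. The steps among them are small: a 1.6-fold lower number from compound 1 to compound 2 (0.20 log units; within the scatter), an at least 1.2-fold higher number from compound 1 to compound 3 (0.09 log units; that floor lies within the scatter) and an at least 1.9-fold higher number from compound 2 to compound 3 (0.29 log units; that floor lies within the scatter). Compound 3 therefore stands at the top of the measured range, at the limit of > 50000 nM in this assay, at which 1 of the 3 values shown sits.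

Compound 4 `Cc1cc(C)nc(Sc2ccc(NC(=O)Nc3ccc(Cl)cc3Cl)cc2)n1` differs from compound 3 only on the aryl attached to the urea nitrogen: 2,4-dichlorophenyl in place of 4-fluorophenyl on an amide-type nitrogen. The measured steps that bear on this change, from compound 1 to compound 2, from compound 1 to compound 3 and from compound 2 to compound 3, all alter a substituent on that same phenyl and all lie within the scatter. On that basis no step beyond the scatter is expected in this assay, with a fair chance that compound 4 again returns only a limit. The step from compound 3 to compound 4 is estimated as a number no higher from compound 3 to compound 4 (the limit leaves the size open). Compound 4 is expected to give about 50000 nM, between 20000 nM and 150000 nM.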

Compound 4, half-maximal inhibitory concentration: > 50000 nM
Compound 4: no number, only a limit; the forecaster's own chance of this, stated with the estimate: 55%; the middle value lies on the limit itself.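

Compound 4 returns a limit and not a number in this assay, which makes 2,4-dichlorophenyl the second halogen-bearing aryl on this amide-type nitrogen to end there, after the 4-fluorophenyl of compound 3: the limit of > 50000 nM in this assay, at which 2 of the 4 values shown sit. The step between compound 3 and compound 4 cannot be read, so these two aryl groups cannot be placed in any order. Against the two compounds that have numbers, the result gives only floors, an at least 1.9-fold higher number from compound 2 to compound 4 (0.29 log units; that floor lies within the scatter) and an at least 1.2-fold higher number from compound 1 to compound 4 (0.09 log units; that floor lies within the scatter), and neither shows a step beyond the scatter.

From the compounds shown here alone, how far the true values of compound 3 and compound 4 lie past the limit stays open. Also open, going by these compounds, is whether a carboxylic acid or an amine on this phenyl would move the number beyond the scatter.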